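The source may report more compounds than this note shows. Statements on the series, on what has been measured and on what is new or still open speak of the compounds shown alone.

Compound 1, `CCc1nn2c(-c3c(COC)cc(OC)cc3OC)cccc2c1N(CC1CCOCC1)CC1CC1`: 120 nM
Compound 2, `COCc1cc(OC)c(-c2cccc3c(N(CC4CCOCC4)CC4CC4)c(C)nn23)c(OC)c1`: 120 nM

Both compounds were tested in an assay on HEK293 cells for displacement of a labelled ligand from corticotropin-releasing factor receptor 1 (Homo sapiens), read by scintillation counting, with a stated time of 2 h; a higher number here means a weaker inhibitor, a lower number a stronger inhibitor. In this assay compound 2 gives 120 nM and compound 1 gives 120 nM; the two values agree to the digits shown, so compound 2 stands level with compound 1, and any gap between them lies within the ordinary scatter of repeated measurements. Compound 3, `COCc1cc(OC)c(-c2cccc3c(N(CC4CCOCC4)CC4CC4)c(C#N)nn23)c(OC)c1`, has not yet been measured in this assay. It differs from compound 2 in a single respect: cyano in place of methyl on an aromatic carbon. Among the compounds with values here, no measured pair shows what such an exchange does on this core, so no step size can be read from the data at hand. The swap of one small group for another at the same spot is expected to move the value only modestly, most likely toward a weaker inhibitor, with a step of a 1.8-fold higher number from compound 2 to compound 3 (0.26 log units; within the scatter). Compound 3 is therefore estimated at 220 nM, within a range from 60 nM to 800 nM.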

Compound 3, half-maximal inhibitory concentration: 52 nM
Compound 3: middle estimate off by 4.2-fold (0.63 log units), on the high side, outside the stated range (below it).
By their numbers in this assay, from the lowest: compound 3; then compounds 1 and 2 (each within the scatter of the next).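

In this assay, cyano in place of methyl on this aromatic carbon gives a 2.3-fold lower number from compound 2 to compound 3 (0.36 log units; beyond the scatter) and so a stronger inhibitor. Compound 1 at 120 nM and compound 2 at 120 nM showed only that ethyl and methyl at this spot stand level, whereas this step shows that the position does respond to the group it carries, here one with a triple bond and a hydrogen-bond acceptor that methyl lacks. Nothing measured here tells which feature of cyano lies behind the change.

On these data alone, whether a plain hydrogen, a chlorine atom or a primary amide on this carbon would move the number the same way remains open. Also open, as far as these compounds go, is whether the exchange gives a similar step when the amine side chain of the shared core is different.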